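Adding a Second Methoxy to the Aryl Ring of Compound 2

The compounds below may be only part of what the source reports. "The series", "measured", "known", "first", "only" and "open" are said of these compounds alone.

Compound 2 `COc1ccc(/C=C/C2CC=CC(=O)O2)cc1` carries a single methoxy group on its aromatic ring. Within the data shown here, in a functional assay on NCI/ADR cells (Homo sapiens) for inhibition, read by sulforhodamine B assay, with a stated time of 48 h (a lower number here means a stronger inhibitor of growth, a higher number a weaker inhibitor of growth), compound 2 gives 17.3 uM, the second highest of the three numbers so far; its nearest neighbour is compound 3 `COc1ccc(/C=C/C2CC=CC(=O)O2)c(OC)c1` at 8.8 uM, and the furthest is compound 1 `O=C1C=CCC(/C=C/c2ccc(C(F)(F)F)cc2)O1` at 54.8 uM. Compound 4 `COc1ccc(/C=C/C2CC=CC(=O)O2)cc1OC` differs from compound 2 by methoxy in place of hydrogen on an aromatic carbon. Among the measured compounds shown here, two measured steps bear on this. Swapping the single substituent gave a 3.2-fold lower number from compound 1 to compound 2 (0.50 log units; beyond the scatter), while adding a second methoxy gave a 2.0-fold lower number from compound 2 to compound 3 (0.29 log units; within the scatter). For the measured compounds named here, the closest precedent is therefore the step of a 2.0-fold lower number from compound 2 to compound 3 (0.29 log units; within the scatter). On that basis compound 4 is expected to shift by a 1.6-fold lower number from compound 2 to compound 4 (0.20 log units; within the scatter). Compound 4 is estimated at 11 uM, between 4.5 uM and 27 uM.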

Compound 4, concentration for growth inhibition (reported as GI): 11.6 uM
Compound 4: the middle estimate sits 1.1-fold (0.02 log units) below what was measured, within the range that was stated.
By their numbers in this assay, from the lowest: compounds 3, 4 and 2 (each within the scatter of the next); then compound 1.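

Putting a methoxy on this ring carbon, ortho to the existing methoxy group, gives a 1.5-fold lower number from compound 2 to compound 4 (0.17 log units; within the scatter), a step that cannot be told apart from no change. The earlier addition of a second methoxy elsewhere on the ring, a 2.0-fold lower number from compound 2 to compound 3 (0.29 log units; within the scatter), also stayed within the scatter, so neither placement has yet produced a clear gain. Nothing available here explains this result. Still open, from the compounds shown here alone, is whether a different group at this carbon, such as an amine, a hydroxyl or a longer ethoxy chain, would move the number beyond the scatter.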